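Series notes: from compound 3 to compound 4

A few compounds are considered here, and "the series" means these few. Any claim that something is new, unique, unknown or untested is made for them only; others in the source may bear on it.

Measured so far in an in vitro ADME assay on microsomes from liver (Homo sapiens) for metabolic stability; on this read-out lower numbers stand for slow clearance and higher numbers for fast clearance:
- compound 1 `CC(C)NC(=O)[C@H]1CC[C@@H](n2/c(=N/C(=O)c3ccc(C#N)c(F)c3)[nH]c3ccc(CN4CCC(C(C)(C)O)CC4)cc32)CC1` gives 132 mL.min-1.g-1 as its value
- compound 2 `CC(C)NC(=O)[C@H]1CC[C@@H](n2/c(=N/C(=O)c3ccc(F)cc3)[nH]c3ccc(CN4CCC[C@H]4C(C)(C)O)cc32)CC1` gives 569 mL.min-1.g-1 as its value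
- compound 3 `CC(C)NC(=O)[C@H]1CC[C@@H](n2/c(=N/C(=O)c3ccc(F)c(F)c3)[nH]c3ccc(CN4CCC(C(C)(C)O)CC4)cc32)CC1` gives 60 mL.min-1.g-1 as its value

In this assay compound 3 at 60 mL.min-1.g-1 is the lowest of the three, and compound 2 at 569 mL.min-1.g-1 is the highest. The next compound is compound 4 `CC(C)NC(=O)[C@H]1CC[C@@H](n2/c(=N/C(=O)c3cc(F)cc(C#N)c3)[nH]c3ccc(CN4CCC(C(C)(C)O)CC4)cc32)CC1`, which has 3-cyano-5-fluorophenyl in place of 3,4-difluorophenyl on a carbonyl carbon. The counted difference is 3-cyano-5-fluorophenyl in place of 3,4-difluorophenyl on a carbonyl carbon for this change.

For the measured compounds named here, one measured step bears on it: a 2.2-fold lower number from compound 1 to compound 3 (0.34 log units; beyond the scatter) with fluoro in place of cyano on an aromatic carbon. Going by the values given here, this step is modest but beyond the scatter, and it is the only single-place comparison available. Compound 4 regains a nitrile, so the same step read in reverse points to a higher number. Among the compounds with values here, no measured compound carries the 3-cyano-5-fluorophenyl group itself, so the transfer is uncertain. Compound 2 differs from compound 3 in more than one place and adds nothing to the estimate.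

The expected change is a 2.1-fold higher number from compound 3 to compound 4 (0.32 log units; beyond the scatter) as an estimate of similar size to the measured step. For compound 4 the estimated value is 125 mL.min-1.g-1 with 55 mL.min-1.g-1 to 280 mL.min-1.g-1 as the expected range.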

Compound 4, intrinsic clearance in microsomes: 90 mL.min-1.g-1
Beside the measured number, compound 4's estimate is 1.4-fold (0.14 log units) above it, within the range that was stated.
By their numbers in this assay, from the lowest: compounds 3, 4 and 1 (each within the scatter of the next, the first and the last beyond it); then compound 2.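

In this assay, the swap of 3,4-difluorophenyl for 3-cyano-5-fluorophenyl on a carbonyl carbon reads as a 1.5-fold higher number from compound 3 to compound 4 (0.18 log units; within the scatter), so this position tolerates the change without a step that can be separated from the scatter. Moving to 3-cyano-5-fluorophenyl from 4-cyano-3-fluorophenyl reads as a 1.5-fold lower number from compound 1 to compound 4 (0.17 log units; within the scatter), so the two nitrile-bearing groups cannot be told apart on this read-out either. The earlier step, a 2.2-fold lower number from compound 1 to compound 3 (0.34 log units; beyond the scatter), therefore does not hold for every nitrile-bearing group at this position: compound 4 carries a nitrile and is not separated from compound 3, although compound 1 is.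

Nothing in the data explains how these aryl groups relate to clearance. For the compounds shown here, it also remains open whether a chloro, methoxy or trifluoromethyl group on this phenyl ring would stay within the scatter of compound 3 and compound 4, or would give a step as clear as the one between compound 1 and compound 3.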